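The compounds below may be only part of what the source reports. "The series", "measured", "known", "first", "only" and "open" are said of these compounds alone.

Measured so far in a functional assay on HEK293 cells with Glucose-dependent insulinotropic receptor (Homo sapiens) as the target, read by cAMP accumulation, with a stated time of 60 min; on this read-out higher numbers stand for larger maximal responses and lower numbers for smaller maximal responses: compound 1 `CCCc1cnc(N2CCC(C3Cc4cc(C5=CCN(S(=O)(=O)CCC)CC5)ccc4O3)CC2)nc1` gives 107%; compound 2 `CCCc1cnc(N2CCC(C3Cc4cc(-c5ccc(S(C)(=O)=O)cc5F)ccc4O3)CC2)nc1` gives 53%; compound 3 `CCCc1cnc(N2CCC(C3Cc4cc(N5CCN(S(=O)(=O)CCC)CC5)ccc4O3)CC2)nc1` gives 74%.

Compound 3 thus stands second of the three numbers, with compound 1 above it and compound 2 below it, both gaps beyond the usual scatter. The step to compound 4 `CCCc1cnc(N2CCC(C3Cc4cc(C5CCN(S(=O)(=O)CCC)CC5)ccc4O3)CC2)nc1` is 1-(propylsulfonyl)piperidin-4-yl in place of 4-(propylsulfonyl)piperazin-1-yl on an aromatic carbon. The group that leaves carries a six-membered non-aromatic ring with two hetero atoms; the group that enters carries a six-membered non-aromatic ring with one hetero atom, joined to the aromatic carbon through a ring carbon rather than a ring nitrogen.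

Going by the values given here, two measured steps bear on this. The closest is a number 33 percentage points lower from compound 1 to compound 3 (beyond the scatter), which is the opposite kind of move: a ring with one hetero atom gave way to a ring with two hetero atoms, and the maximal response fell. Also, a number 21 percentage points higher from compound 2 to compound 3 (beyond the scatter) and a number 54 percentage points lower from compound 1 to compound 2 (beyond the scatter) show that this part of the molecule steers the maximal response strongly. Among the compounds with values here, a rise in this assay beyond the scatter is therefore expected, roughly a number 21 percentage points higher from compound 3 to compound 4 (beyond the scatter), though no measured pair tests exactly this ring.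

The estimate for compound 4 in this assay is 95%, with a likely range from 75% to 115%.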

Compound 4, largest response reached (Emax), in percent of the reference or control that the assay uses: 43%
The estimate for compound 4 lay 52 percentage points above the measured number; the whole stated range lies above it.
By their numbers in this assay, from the lowest: compounds 4 and 2 (each within the scatter of the next); then compound 3; then compound 1.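

Swapping the ring with two hetero atoms for one with a single hetero atom does not by itself lift the maximal response in this assay, since this change gives a number 31 percentage points lower from compound 3 to compound 4 (beyond the scatter) and so runs against the rise suggested by the earlier compounds. Two groups of equal heavy-atom count, each with a single hetero atom in the ring and differing by one carbon-carbon double bond in that ring, show a number 64 percentage points lower from compound 1 to compound 4 (beyond the scatter) and thus reveal that the count of ring hetero atoms does not decide the outcome at this position. The 1-(propylsulfonyl)piperidin-4-yl and 2-fluoro-4-(methylsulfonyl)phenyl groups cannot be told apart here, with a number 10 percentage points lower from compound 2 to compound 4 (within the scatter) separating them despite their different rings. Nothing available explains why these closely related rings give such different maximal responses.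

On these data alone, it remains open whether the high response of compound 1 survives when its propylsulfonyl chain is replaced by a shorter methylsulfonyl or ethylsulfonyl group. An acetyl group or a methyl carbamate on the ring nitrogen would also show whether the sulfonyl group is needed at all.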